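The compounds below may be only part of what the source reports. "The series", "measured", "known", "first", "only" and "open" are said of these compounds alone.

Working notes on the series. Compound 3 `C=CCn1c(=O)/c(=C\c2ccccc2OC)[nH]c(=O)/c1=C\c1ccccc1OC` is the reference point here: in a functional assay on NCI-H1975 cells (Homo sapiens) for cytotoxicity, read by CCK-8 assay, with a stated time of 72 h (a lower number here means a stronger inhibitor, a higher number a weaker inhibitor), compound 3 gives 21500 nM. Compound 1 `C=CCn1c(=O)/c(=C\c2cccc(C)c2)[nH]c(=O)/c1=C\c1ccccc1OC` gives 32800 nM in this assay, and the two values lie within the scatter of each other, so no order between compound 1 and compound 3 is claimed. Compound 2 `COc1ccccc1/C=c1/[nH]c(=O)/c(=C\c2ccccc2OC)[nH]c1=O` gives "not active" (no number reported) in this assay, with no number attached. Among the measured compounds shown here, the one single-site step seen so far, a 1.5-fold lower number from compound 1 to compound 3 (0.18 log units; within the scatter), exchanged one aryl group for another at the same place and stayed within the scatter. Compound 4 `C=CCn1c(=O)/c(=C\c2ccc(C)cc2)[nH]c(=O)/c1=C\c1ccccc1OC` differs from compound 3 by 4-methylphenyl in place of 2-methoxyphenyl on a double-bonded chain carbon bound to an aromatic carbon. Because a 1.5-fold lower number from compound 1 to compound 3 (0.18 log units; within the scatter) shifted nothing beyond the scatter, the expected step of a 1.3-fold higher number from compound 3 to compound 4 (0.11 log units; within the scatter) is likewise no change beyond the scatter. Compound 4 is therefore estimated at 28000 nM, with a range of 12000 nM to 65000 nM.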

Compound 4, half-maximal inhibitory concentration: "not active" (no number reported)
Compound 4: no number reported; there is nothing to compare the estimate with.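

Among the compounds shown here, compound 4 carries no number, so no step from compound 3 to compound 4 can be read. The compounds shown leave open how far compound 4 lies from compound 3. No supporting evidence bears on this result.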